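Bromo to hydroxy on the chain of compound 3

The source may hold more compounds than are shown below. What is called first, only, known or untested is meant among the compounds shown, and "the series" means these compounds.

Measured in an ADME assay on Vero cells (Chlorocebus sabaeus) for inhibition, read by fluorescence and resazurin assay, with a stated time of 24 h; a higher number here means that more compound is tolerated, a lower number that less compound is tolerated
- compound 1 `COC(=O)CCn1c2ccc([N+](=O)[O-])cc2c(=O)n1Cc1ccccc1` gives "not determined" (no result reported)
- compound 2 `Cc1ccc(S(=O)(=O)n2c3ccc([N+](=O)[O-])cc3c(=O)n2Cc2ccccc2)cc1` gives "not determined" (no result reported)
- compound 3 `O=[N+]([O-])c1ccc2nn(Cc3ccccc3)c(OCCCBr)c2c1` gives 539000 nM

Among the measured compounds shown here, compound 3 holds the only number so far, since neither compound 1 nor compound 2 has a reported result. For the measured compounds named here, it therefore cannot be ranked against anything, and no measured step offers a guide to the next change.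

Compound 4 `O=[N+]([O-])c1ccc2nn(Cc3ccccc3)c(OCCCO)c2c1` is related to compound 3 by the difference hydroxy in place of bromo on a saturated chain carbon, three bonds along the chain from an oxygen on an aromatic ring with hydroxy in place of bromo on a saturated chain carbon, three bonds along the chain from an oxygen on an aromatic ring. The 3-bromopropyl group thus becomes 3-hydroxypropyl.

Going by the values given here, with no comparable pair measured, only a small shift is expected, toward more compound tolerated. The estimated step of a 1.2-fold higher number from compound 3 to compound 4 (0.08 log units; within the scatter) is not expected to go beyond the usual scatter. In this assay the expected value for compound 4 is 650000 nM within an estimated range from 250000 nM to 1500000 nM until the measurement is available.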

Compound 4, half-maximal cytotoxic concentration: > 300000 nM
Compound 4: only a limit was reported (the forecaster's own chance of this, stated with the estimate: 25%); the middle value is on the limit's open side.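

In this assay, among the compounds shown here, compound 4 gives > 300000 nM, which is a limit and not a number, so no step from compound 3 to compound 4 can be read. The compounds shown leave open whether hydroxy in place of bromo on this chain changes the tolerated concentration at all.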